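A few compounds are considered here, and "the series" means these few. Any claim that something is new, unique, unknown or untested is made for them only; others in the source may bear on it.

Measured compounds:
Compound 1, `CC(C)(C)OC(=O)/N=C(\NC1=NC(=O)CN1C(C)(C)C)Nc1ccc(Cl)c(Cl)c1`, gives < 0.167 h in an in vivo ADME assay on the whole organism for metabolic stability, with Homo sapiens as the target, read by LC-MS, at a dose of 160 mg/kg by the oral route (a higher number here means that the compound lasts longer, a lower number that the compound disappears faster), a limit of the assay.
Compound 2, `CC(C)N1CC(=O)N=C1N/C(=N\C(C)(C)C)Nc1ccc(Cl)c(Cl)c1`, gives 0.662 h in this assay.
Compound 3, `CC(C)N1CC(=O)N=C1N/C(=N\C(=O)C(C)(C)C)Nc1ccc(Cl)c(Cl)c1`, gives > 1 h in this assay, a limit of the assay.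

Compound 3 therefore stands at the upper limit, as noted in the limit of > 1 h in this assay, at which 1 of the 3 values shown sits. Within the data shown here, the only measured step that changes the group on the double-bonded nitrogen is an at least 1.5-fold higher number from compound 2 to compound 3 (0.17 log units; that floor lies within the scatter). Compound 4, `CC(C)N1CC(=O)N=C1N/C(=N\C(=O)OC(C)(C)C)Nc1ccc(Cl)c(Cl)c1`, differs from compound 3 by tert-butoxy in place of tert-butyl on a carbonyl carbon. Compound 1 also carries a tert-butoxycarbonyl group on that nitrogen and sits at the lower limit noted in the limit of < 0.167 h in this assay, at which 1 of the 3 values shown sits, though its ring nitrogen substituent differs as well. The step from compound 3 to compound 4 is therefore expected to be downward, an at least 1.6-fold lower number from compound 3 to compound 4 (0.22 log units; that floor lies within the scatter), with wide uncertainty. Compound 4 is estimated at 0.6 h, range 0.15 h to 2.5 h.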

Compound 4, half-life: 0.213 h
Compound 4: middle estimate off by 2.8-fold (0.45 log units), on the high side; the range from low to high includes it.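

Among these compounds, on the carbonyl carbon whose other neighbour is the amide-type nitrogen, tert-butoxy in place of tert-butyl gives an at least 4.6-fold lower number from compound 3 to compound 4 (0.67 log units; beyond the scatter), the first single change here whose step is printed as beyond the scatter. Tert-butoxycarbonyl in place of tert-butyl on the double-bonded nitrogen gives a 3.1-fold lower number from compound 2 to compound 4 (0.49 log units; beyond the scatter), whereas (tert-butyl)carbonyl there gave only a floor within the scatter. Hydrogen in place of methyl on the saturated chain carbon gives an at least 1.2-fold higher number from compound 1 to compound 4 (0.10 log units; that floor lies within the scatter), which fixes no size.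

As far as these compounds go, what an amine or a longer chain on that carbonyl carbon would give remains open.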